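Replacing the 3-oxomorpholin-4-yl group of compound 3

This account rests on a few compounds, and the source may have more. Where it says the series, first, only, none or still open, it means among the compounds named here.

In a physicochemical assay for solubility, read by HPLC, in phosphate buffer, at pH 6.5 (on this read-out lower numbers stand for lower solubility and higher numbers for higher solubility), compound 3 (`COC(=O)C1=C(CN2CCOCC2=O)NC(c2nccs2)=NC1(C)c1ccc(F)cc1`) gives 440 ug/mL and sits within the scatter of compound 1 (`COC(=O)C1=C(C)NC(c2nccs2)=NC1(C)c1ccc(S(C)(=O)=O)cc1`) at 365 ug/mL and of compound 2 (`COC(=O)C1=C(CN2CC3CC2CO3)NC(c2nccs2)=NC1(C)c1ccc(F)cc1`) at 564 ug/mL on these three numbers. Compound 4 (`COC(=O)C1=C(CN2CCCS2(=O)=O)NC(c2nccs2)=NC1(C)c1ccc(F)cc1`) differs from compound 3 by one change (a group of 7 heavy atoms (3 carbon, 1 nitrogen, 2 oxygen, 1 sulfur; one five-membered non-aromatic ring with 2 hetero atoms) in place of a group of 7 heavy atoms (4 carbon, 1 nitrogen, 2 oxygen; one six-membered non-aromatic ring with 2 hetero atoms), on a saturated chain carbon bound to a double-bonded ring carbon). Within the data shown here, the only measured step at this place (a 1.3-fold lower number from compound 2 to compound 3 (0.11 log units; within the scatter)) stayed within the scatter, and it too exchanged one non-aromatic ring group for another. Among the measured compounds shown here, no measured compound carries the entering group, so this support is thin. No step beyond the scatter is therefore expected in this assay for this change. The estimated step to compound 4 is small (a 1.0-fold lower number from compound 3 to compound 4 (0.02 log units; within the scatter)) and stays within the scatter. For compound 4 the expected value is 420 ug/mL (estimated range 210 ug/mL to 840 ug/mL).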

Compound 4, solubility: 125 ug/mL
The estimate for compound 4 lay 3.4-fold (0.53 log units) above the measured number; the whole stated range lies above it.
By their numbers in this assay, from the lowest: compound 4; then compounds 1, 3 and 2 (each within the scatter of the next).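

In this assay the place on the saturated chain carbon proves sensitive to the group it carries: the sulfur-bearing five-membered ring brings a 3.5-fold lower number from compound 3 to compound 4 (0.55 log units; beyond the scatter) and a 4.5-fold lower number from compound 2 to compound 4 (0.65 log units; beyond the scatter) while the exchange between the two ring groups without sulfur stays within the scatter. Equal heavy-atom, donor and acceptor counts therefore do not make these groups read alike here. Nothing available accounts for the drop.

Still open, as far as these compounds go, is whether the sulfur or the single five-membered ring goes with the lower number. From the compounds shown here alone, how a simple dimethylamine or a carboxylic acid on this carbon would read also remains unknown.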